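Removing One Fluoro Group From Compound 3

The compounds below may be only part of what the source reports. "The series", "measured", "known", "first", "only" and "open" are said of these compounds alone.

Compound 1 `Cc1ccc(/C=C/c2cccc(F)c2)cc1` gives 800 nM in an assay on HepG2 cells for activation of nuclear factor erythroid 2-related factor 2 (Homo sapiens), read by a luciferase reporter, with a stated time of 5 h; on this read-out lower numbers stand for an effect already at smaller amounts and higher numbers for an effect only at larger amounts of compound.
Compound 2 `Cc1ccc(/C=C/c2ccc(F)c(F)c2)cc1` gives 2600 nM in this assay.
Compound 3 `Fc1ccc(/C=C/c2ccccc2F)cc1F` reaches only a limit of the assay, > 15000 nM in this assay.

Compound 1 and compound 2 share a core and differ in one place: hydrogen in place of fluoro on an aromatic carbon. That change produced a 3.3-fold lower number from compound 2 to compound 1 (0.51 log units; beyond the scatter), a step beyond the usual scatter.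

Compound 3 carries a different core, and how the core of compound 3 differs from the core of compound 2 is not broken down here. For compound 3 no number is known, only the limit (the limit of > 15000 nM in this assay, at which 1 of the 3 values shown sits), so its value lies somewhere beyond that edge.

Compound 4 `Fc1cccc(/C=C/c2ccccc2F)c1` is yet to be measured. It differs from compound 3 in one place: hydrogen in place of fluoro on an aromatic carbon. This is the same change as that from compound 2 to compound 1, made at a place described in the same words.

By analogy with that earlier step, a step of similar size is expected in this assay, so compound 4 is expected to show an at least 1.2-fold lower number from compound 3 to compound 4 (0.09 log units; that floor lies within the scatter). Because the starting point is only the limit (the limit of > 15000 nM in this assay, at which 1 of the 3 values shown sits), the endpoint is uncertain, and compound 4 may again fall at a limit. The estimate for compound 4 is 12000 nM, expected to lie between 4000 nM and 40000 nM.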

Compound 4, half-maximal effective concentration: > 15000 nM
Compound 4 ended at the assay's limit; the forecaster's own chance of this, stated with the estimate: 45%; middle value at least 1.2-fold (0.09 log units) away from the limit.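

Compound 3 and compound 4 both sit at a limit of this assay rather than at a number, so the step between them cannot be read: the limit of > 15000 nM in this assay, at which 2 of the 4 values shown sit.

The compounds shown leave open how far swapping this fluoro group for hydrogen moves the value in the core of compound 3, and whether the same change would act there as it does between compound 2 and compound 1.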